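The source may hold more compounds than are shown below. What is called first, only, known or untested is meant among the compounds shown, and "the series" means these compounds.

Compound 1 `Cn1c(=O)c(S(=O)(=O)c2ccc(F)cc2F)cc2cnc(Nc3ccc4cc[nH]c4c3)nc21` gives 5000 nM in a functional assay on DU-145 cells (Homo sapiens) for inhibition, read by trypan blue exclusion, with a stated time of 72 h (a higher number here means a weaker inhibitor, a lower number a stronger inhibitor), which is the second highest of the three numbers in hand. In this assay compound 2 `Cn1c(=O)c(S(=O)(=O)c2ccccc2)cc2cnc(Nc3ccc4cc[nH]c4c3)nc21` gives 10000 nM, and compound 3 `Cn1c(=O)c(S(=O)(=O)Cc2ccc(F)cc2F)cc2cnc(Nc3ccc4[nH]ccc4c3)nc21` gives 1000 nM. Compound 4 `Cn1c(=O)c(S(=O)(=O)c2ccc(F)cc2F)cc2cnc(Nc3ccc4[nH]c(C(=O)O)cc4c3)nc21` differs from compound 1 as follows: 2-carboxy-1H-indol-5-yl in place of 1H-indol-6-yl on a nitrogen on an aromatic ring. For the measured compounds named here, the only measured step, a 2.0-fold higher number from compound 1 to compound 2 (0.30 log units; within the scatter), concerns the group on the sulfonyl sulfur and therefore does not bear on the amine substituent; compound 3 differs from compound 1 in two places at once, so its value cannot be assigned to either change alone. Going by the values given here, with no measured step addressing this substituent, no step beyond the scatter is expected: the estimated step is no change at the digits printed from compound 1 to compound 4 (within the scatter). Compound 4 is therefore expected near 5000 nM, in a range from 1500 nM to 15000 nM.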

Compound 4, half-maximal inhibitory concentration: 10000 nM
For compound 4 the middle estimate is 2.0-fold (0.30 log units) below the measured one; the range from low to high includes it.
By their numbers in this assay, from the lowest: compound 3; then compounds 1, 2 and 4 (each within the scatter of the next).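

In this assay, for the compounds shown here, the first reading at the group on this nitrogen, 2-carboxy-1H-indol-5-yl in place of 1H-indol-6-yl, gives a 2.0-fold higher number from compound 1 to compound 4 (0.30 log units; within the scatter). This position therefore takes the larger group with its carboxylic acid without a step beyond the scatter. Nothing measured here offers an explanation for this reading.

The swap alters both the point of attachment on the indole and the carboxy group, and the compounds shown do not separate the two. As far as these compounds go, whether an unsubstituted 1H-indol-5-yl, a methyl ester or a primary amide would read the same on this core remains open.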